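Methoxy on the phenol ring of compound 1

This account rests on a few compounds, and the source may have more. Where it says the series, first, only, none or still open, it means among the compounds named here.

Three thiosemicarbazones that share one core have been tested in a functional assay on MGC-803 cells (Homo sapiens) for antiproliferative activity, read by MTT assay, with a stated time of 72 h; on this read-out lower numbers stand for stronger inhibition and higher numbers for weaker inhibition. Compound 1 `Oc1ccccc1/C=N/NC(=S)N1CCOCC1` gives 29200 nM in this assay. Compound 2 `Oc1ccc(Cl)cc1/C=N/NC(=S)N1CCOCC1` gives 16300 nM, and compound 3 `Oc1c(Br)cc(Br)cc1/C=N/NC(=S)N1CCOCC1` gives 20400 nM. Compound 1 stands highest of the three numbers, yet its gaps to compound 2 and to compound 3 both lie within the scatter, so no order among them can be read.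

Compound 4 `COc1ccc(/C=N/NC(=S)N2CCOCC2)c(O)c1` is not yet measured. It differs from compound 1 by methoxy in place of hydrogen on an aromatic carbon. Within the data shown here, the only measured step that bears on it is the single change on the same ring, a 1.8-fold lower number from compound 1 to compound 2 (0.25 log units; within the scatter). That step stayed within the scatter, and the two substituents of compound 3 also left the number close to compound 1. A substituent added to this ring has so far moved nothing beyond the scatter, so no step beyond it is expected here either. Compound 4 is therefore expected to give 25000 nM in this assay, within 10000 nM to 60000 nM, meaning an expected 1.2-fold lower number from compound 1 to compound 4 (0.07 log units; within the scatter).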

Compound 4, half-maximal inhibitory concentration: 56100 nM
Compound 4: the middle estimate sits 2.2-fold (0.35 log units) below what was measured, and the stated range covers the measured number.
By their numbers in this assay, from the lowest: compounds 2, 3, 1 and 4 (each within the scatter of the next, the first and the last beyond it).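

In this assay, methoxy in place of hydrogen on an aromatic carbon, meta to a hydroxy group and para to a large group, gives a 1.9-fold higher number from compound 1 to compound 4 (0.28 log units; within the scatter) and so adds a second single change on this ring that stays within the scatter. The chloro step is printed in the other direction as a 1.8-fold lower number from compound 1 to compound 2 (0.25 log units; within the scatter) but is also within the scatter, so neither step shows a real effect or a real direction, and an oxygen-linked group has so far done no more here than a halogen. No measurement on hand offers an explanation for this result.

As far as these compounds go, whether an amine, a carboxylic acid or a longer chain such as ethoxy on this same carbon would move the number beyond the scatter stays open. Also open, from the compounds shown here alone, is whether methoxy on another carbon of the ring would behave as it does here.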